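Swapping an aryl amide for a pyridyl amide in a cytotoxicity series

This account rests on a few compounds, and the source may have more. Where it says the series, first, only, none or still open, it means among the compounds named here.

The three measured compounds share a quinoline-type core substituted with an aryloxy or benzyloxy side chain. Compound 1 `Cc1cc(C)cc(NC(=O)COc2cc(C)nc3ccc(OCc4ccccc4)cc23)c1` was tested in a toxicity assay on HepG2 cells (Homo sapiens) for inhibition, read by CellTiter-Glo, with a stated time of 48 h; on this read-out lower numbers stand for stronger inhibition and higher numbers for weaker inhibition. In this assay compound 1 returns only a limit, > 100000 nM, not a number. For the measured compounds named here, compound 2 `COc1ccc2nc(C)cc(OCc3ccc4ccccc4n3)c2c1` is the only one with a true value, giving 31600 nM in this assay. Compound 3 `COc1ccc(NC(=O)COc2cc(C)nc3ccc(OC)cc23)cc1` also gives only a limit in this assay, > 100000 nM, so no number is known for it. Compound 3 therefore stands at the edge of what this assay can report, and the limit of > 100000 nM in this assay, at which 2 of the 3 values shown sit, shows that this is where most of the measured set sits; only compound 2 falls inside the range that yields a figure.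

Compound 4 `COc1ccc2nc(C)cc(OCC(=O)Nc3cccnc3)c2c1` has not been measured in this assay. It differs from compound 3 by pyridin-3-yl in place of 4-methoxyphenyl on an amide-type nitrogen. Going by the values given here, no measured pair shows what this particular exchange does, so the data give no basis for a step in either direction. Since compound 3 registers only a limit, compound 4 is expected to behave alike, with no step beyond the scatter, and the step that the limit leaves unreadable from compound 3 to compound 4 is meant as essentially flat. Compound 4 is expected to give about 120000 nM in this assay, within 40000 nM to 300000 nM, most probably reported again as a limit.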

Compound 4, half-maximal inhibitory concentration: > 100000 nM
Compound 4: no number, only a limit (the forecaster's own chance of this, stated with the estimate: 75%); the middle value does not contradict the limit.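

In this assay compound 4 gives > 100000 nM, which is a limit and not a number. Compound 3 also stands at a limit, so no step can be read between compound 3 and compound 4. The compounds shown leave open whether pyridin-3-yl in place of 4-methoxyphenyl on an amide-type nitrogen changes the inhibition at all.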